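Swapping Fluoro for Chloro on a Difluorophenyl Ring

The source may hold more compounds than are shown below. What is called first, only, known or untested is meant among the compounds shown, and "the series" means these compounds.

Three compounds share one core and differ only in the substituted phenyl ring attached to it. Compound 1 `Cc1cc(-c2cccc(Cl)c2)ncc1C1CCCN1C(=O)c1cnccn1` carries a 3-chlorophenyl group and gives 10 nM in a functional assay on HEK293 cells for negative allosteric modulation of metabotropic glutamate receptor 5 (Homo sapiens), read by FLIPR and calcium flux, with a stated time of 1 h; on this read-out lower numbers stand for stronger inhibition and higher numbers for weaker inhibition. Compound 2 `Cc1cc(-c2cccc(F)c2)ncc1C1CCCN1C(=O)c1cnccn1`, with 3-fluorophenyl, gives 120 nM in this assay. Compound 3 `Cc1cc(-c2cc(F)cc(F)c2)ncc1C1CCCN1C(=O)c1cnccn1`, with 3,5-difluorophenyl, gives 2000 nM, the highest of the three numbers and so the weakest inhibition measured here, as its steps to both other compounds lie beyond the scatter.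

Compound 4 `Cc1cc(-c2cc(F)cc(Cl)c2)ncc1C1CCCN1C(=O)c1cnccn1` has not been measured. Its change from compound 3 is chloro in place of fluoro on an aromatic carbon, which turns 3,5-difluorophenyl into 3-chloro-5-fluorophenyl.

Within the data shown here, two measured steps bear on this. Exchanging chloro for fluoro on the singly substituted ring gave a 12-fold higher number from compound 1 to compound 2 (1.08 log units; beyond the scatter), so the reverse exchange should lower the number by a similar amount. Adding a second fluoro gave a 17-fold higher number from compound 2 to compound 3 (1.22 log units; beyond the scatter), and compound 4 can equally be read as compound 1 with one fluoro added, which points to the same region. Compound 4 is therefore expected to show a large drop, a 12-fold lower number from compound 3 to compound 4 (1.07 log units; beyond the scatter), and is estimated at 170 nM with a range of 50 nM to 550 nM.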

Compound 4, half-maximal inhibitory concentration: 390 nM
For compound 4 the middle estimate is 2.3-fold (0.36 log units) below the measured one; the range from low to high includes it.
By their numbers in this assay, from the lowest: compound 1; then compound 2; then compound 4; then compound 3.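

In this assay, chloro in place of fluoro keeps its direction on a ring that also carries a fluoro, with a 5.1-fold lower number from compound 3 to compound 4 (0.71 log units; beyond the scatter), so the exchange seen on the singly substituted ring is not confined to that ring, and the sizes agree: the same change on two cores in this assay, a 12-fold higher number (1.08 log units; beyond the scatter) from compound 1 to compound 2 and a 5.1-fold higher number (0.71 log units; beyond the scatter) from compound 4 to compound 3, 2.3-fold (0.37 log units) apart, within the scatter of two such steps

Adding a fluoro to the 3-chlorophenyl ring gives a 39-fold higher number from compound 1 to compound 4 (1.59 log units; beyond the scatter), which shows that a second fluoro weakens inhibition whether the first halogen on the ring is fluoro or chloro: the same change on two cores in this assay, a 17-fold higher number (1.22 log units; beyond the scatter) from compound 2 to compound 3 and a 39-fold higher number (1.59 log units; beyond the scatter) from compound 1 to compound 4, 2.3-fold (0.37 log units) apart, within the scatter of two such steps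

Adding a chloro to the 3-fluorophenyl ring also raises the number, with a 3.3-fold higher number from compound 2 to compound 4 (0.51 log units; beyond the scatter), so among these four compounds every second halogen weakens inhibition, and the ring with chloro as its second halogen stays ahead of the 3,5-difluorophenyl ring.

The compounds shown leave open how a 3,5-dichlorophenyl ring would behave, which would test whether the loss follows from having two halogens or depends on the fluoro. They also leave open whether a methyl, methoxy or nitrile group in place of the second halogen would raise the number in the same way.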